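A Chlorophenyl in Place of a Dimethoxyphenyl

The source may hold more compounds than are shown below. What is called first, only, known or untested is meant among the compounds shown, and "the series" means these compounds.

For the measured compounds named here, compound 1, `COc1ccc(-c2cc(-c3cc(C(C)C)c(O)cc3C)[nH]c(=O)c2C#N)c(OC)c1`, is one of two compounds measured in a functional assay for inhibition, tested at 20 ug/mL (on this read-out lower numbers stand for a weaker effect and higher numbers for a stronger effect at the one concentration tested), where compound 1 gives 27%. Compound 2, `COc1ccc(-c2cc(-c3cc(C(C)C)c(O)cc3C)[nH]c(=O)c2C#N)cc1`, gives 24% in this assay, and the step of a number 3 percentage points lower from compound 1 to compound 2 (within the scatter) shows that dropping one methoxy group leaves the read-out essentially unchanged. Compound 1 thus holds the higher of the two numbers, though its gap to compound 2 lies within the scatter. Compound 3, `Cc1cc(O)c(C(C)C)cc1-c1cc(-c2ccccc2Cl)c(C#N)c(=O)[nH]1`, differs from compound 1 by 2-chlorophenyl in place of 2,4-dimethoxyphenyl on an aromatic carbon. Going by the values given here, only the step from compound 1 to compound 2 bears on this change, and it covered a single methoxy group; the present change removes both methoxy groups and brings in a chlorine, so it reaches further than anything measured here. Since that one measured step was small, the expectation for compound 3 is no movement beyond the scatter, a number 2 percentage points lower from compound 1 to compound 3 (within the scatter). Compound 3 is estimated at 25%, with a range from 10% to 40%.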

Compound 3, a percentage reported as inhibition, at one concentration (the size of the read-out at that concentration, not a potency): 12%
The estimate for compound 3 lay 13 percentage points above the measured number; low and high end bracket the measured number.
By their numbers in this assay, from the lowest: compound 3; then compounds 2 and 1 (each within the scatter of the next).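

The group opposite the ring nitrogen is not indifferent to change: in this assay, 2-chlorophenyl in place of 2,4-dimethoxyphenyl gives a number 15 percentage points lower from compound 1 to compound 3 (beyond the scatter), and in place of 4-methoxyphenyl it gives a number 12 percentage points lower from compound 2 to compound 3 (beyond the scatter). For the compounds shown here, removing a single methoxy group had moved the read-out only within the scatter, so this is the first change at this position to go beyond it, though the effect remains modest. Nothing available explains the loss of effect at this position.

Each step removes methoxy and adds chlorine together, so the compounds shown cannot tell which of the two matters. A plain phenyl ring would separate them, and a phenyl ring carrying an amine or a carboxylic acid would test quite different groups here.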